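Furan to thiophene on the para-aryl of a tricyclic scaffold

This account rests on a few compounds, and the source may have more. Where it says the series, first, only, none or still open, it means among the compounds named here.

Three compounds sharing one core have been run in an assay on isolated protein for agonist activity at Bile acid receptor (Homo sapiens), read by AlphaScreen, with a stated time of 30 min; on this read-out lower numbers stand for an effect already at smaller amounts and higher numbers for an effect only at larger amounts of compound. Compound 1 `Cc1ccccc1-n1nc(C)c2c1NC(=O)[C@H](C)S[C@@H]2c1ccc(-c2ccoc2)cc1` gives 3500 nM in this assay. Its number sits at the upper end of the three, yet the other two do not differ from it beyond the scatter: compound 2 `Cc1ccc(-n2nc(C)c3c2NC(=O)[C@H](C)S[C@@H]3c2ccc(Oc3ccccc3)cc2)cc1` gives 3400 nM in this assay, and compound 3 `Cc1nn(-c2ccccc2C(F)(F)F)c2c1C(c1ccc(Oc3ccccc3)cc1)SC(C)C(=O)N2` gives 2000 nM. Among the measured compounds shown here, no single-point step between measured compounds is available, so no measured effect of a change of this kind can be quoted.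

Compound 4 `Cc1ccccc1-n1nc(C)c2c1NC(=O)[C@H](C)S[C@@H]2c1ccc(-c2ccsc2)cc1` has not yet been measured. It differs from compound 1 by thiophen-3-yl in place of furan-3-yl on an aromatic carbon. As nothing among the three measured compounds speaks to such a change, the step is expected to be small, in no firm direction, and most likely within the scatter. Compound 4 is therefore expected to give about 2800 nM in this assay, with a range from 1000 nM to 8000 nM. This expectation amounts to a step of a 1.3-fold lower number from compound 1 to compound 4 (0.10 log units; within the scatter).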

Compound 4, half-maximal effective concentration: 1400 nM
Estimate against measurement, compound 4: 2.0-fold (0.30 log units) above; the measured number falls inside the stated range.
By their numbers in this assay, from the lowest: compounds 4, 3, 2 and 1 (each within the scatter of the next, the first and the last beyond it).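

Thiophen-3-yl in place of furan-3-yl gives a 2.5-fold lower number from compound 1 to compound 4 (0.40 log units; beyond the scatter) in this assay, a modest step and the first single-point change in the series that can be read. It shows that this place, on an aromatic carbon para to a large group, responds to the exchange even though the two groups match in heavy-atom count, ring size and counted donors and acceptors, with sulfur in place of oxygen as the only difference in those counts. Nothing available bears on what lies behind this step.

From the compounds shown here alone, whether a pyridine ring, an amine or a carboxylic acid at this place would give a lower or a higher number remains open. Going by these compounds, it is also open whether the same exchange would give a similar step with other groups elsewhere on the shared core.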